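From a 4-hydroxycyclohexyl ether to an oxan-4-yl ether

The compounds below may be only part of what the source reports. "The series", "measured", "known", "first", "only" and "open" are said of these compounds alone.

Of the compounds shown here, three sharing one core have been measured in an assay on HEK293 cells for inhibition of N-acylethanolamine-hydrolyzing acid amidase (Rattus norvegicus), read by LC-MS, with a stated time of 30 min; a lower number here means a stronger inhibitor, a higher number a weaker inhibitor. Compound 1 `O=C1OCCN1C(=O)c1ccc(Oc2ccccc2)cc1` gives 680 nM, compound 2 `CCCCCCOc1ccc(C(=O)N2CCOC2=O)cc1` gives 640 nM, and compound 3 `O=C1OCCN1C(=O)c1ccc(OC2CCC(O)CC2)cc1` gives 210 nM. Compound 3 thus stands lowest of the three, and both other compounds lie beyond the scatter from it: a 3.2-fold lower number from compound 1 to compound 3 (0.51 log units; beyond the scatter) and a 3.0-fold lower number from compound 2 to compound 3 (0.48 log units; beyond the scatter). Between the first two the change is small, a 1.1-fold lower number from compound 1 to compound 2 (0.03 log units; within the scatter).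

Compound 4 `O=C1OCCN1C(=O)c1ccc(OC2CCOCC2)cc1` differs from compound 3 in one place: oxan-4-yl in place of 4-hydroxycyclohexyl on an oxygen on an aromatic ring. Among the compounds with values here, no measured step covers this exact exchange. The two steps that touch the same position, a 3.2-fold lower number from compound 1 to compound 3 (0.51 log units; beyond the scatter) and a 3.0-fold lower number from compound 2 to compound 3 (0.48 log units; beyond the scatter), show that the 4-hydroxycyclohexyl ether lowers the number modestly against either phenyl or hexyl, but neither tells what happens when that ring, with its one hydrogen-bond donor, gives way to a ring with one hetero atom and no donor. The expectation is therefore that compound 4 lands between compound 3 and the other two, a modest rise in this assay, a 1.7-fold higher number from compound 3 to compound 4 (0.22 log units; within the scatter). The estimate for compound 4 is 350 nM, with a range from 150 nM to 900 nM.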

Compound 4, half-maximal inhibitory concentration: 330 nM
Compound 4: the middle estimate sits 1.1-fold (0.03 log units) above what was measured, and the stated range covers the measured number.
By their numbers in this assay, from the lowest: compounds 3, 4, 2 and 1 (each within the scatter of the next, the first and the last beyond it).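

In this assay, exchanging 4-hydroxycyclohexyl, with 1 hydrogen-bond donor, for oxan-4-yl, with 0 hydrogen-bond donors, on the oxygen on the aromatic ring gives a step within the scatter (a 1.6-fold higher number from compound 3 to compound 4 (0.20 log units; within the scatter)), so the donor of compound 3 can be given up at this position without a change that these data can separate from the scatter. Against the other two ethers, the oxan-4-yl group stands apart only in part: the step from the phenyl ether lies beyond the scatter (a 2.1-fold lower number from compound 1 to compound 4 (0.31 log units; beyond the scatter)), the step from the hexyl ether within it (a 1.9-fold lower number from compound 2 to compound 4 (0.29 log units; within the scatter)), whereas the 4-hydroxycyclohexyl ether stood clear of the hexyl ether (a 3.0-fold lower number from compound 2 to compound 3 (0.48 log units; beyond the scatter)). Nothing available here accounts for these steps.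

The compounds shown leave open how a ring with a nitrogen in it, such as piperidin-4-yl, or a 4-aminocyclohexyl or 4-carboxycyclohexyl ether would behave at this oxygen. They also leave open whether a hydroxyl on an open chain, as in a 6-hydroxyhexyl ether, would differ from the plain hexyl ether of compound 2.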